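The source may report more compounds than this note shows. Statements on the series, on what has been measured and on what is new or still open speak of the compounds shown alone.

Going by the values given here, compound 2 `CCCN(CC[C@H]1CC[C@H](NC(=O)/C=C/c2cccc(Cl)c2)CC1)[C@H]1CCc2nc(N)sc2C1` gives 1.2 nM in an assay on brain for displacement of a labelled ligand from D(3) dopamine receptor (Rattus norvegicus) (a higher number here means a weaker inhibitor, a lower number a stronger inhibitor), the lowest of the two numbers so far; compound 1 `CCCN(CC[C@H]1CC[C@H](NC(=O)/C=C/c2cccc(F)c2)CC1)[C@H]1CCc2nc(N)sc2C1` gives 9.9 nM in this assay. Among the compounds with values here, the one measured step, an 8.3-fold lower number from compound 1 to compound 2 (0.92 log units; beyond the scatter), shows that the group on the aromatic ring moves this assay by a modest but real amount. Compound 3 `CCCN(CC[C@H]1CC[C@H](NC(=O)/C=C/c2ccc(OC)cc2)CC1)[C@H]1CCc2nc(N)sc2C1` carries the change (4-methoxyphenyl in place of 3-chlorophenyl on a double-bonded chain carbon bound to a double-bonded chain carbon). Within the data shown here, no measured step matches this swap; the only guide is that the aryl substituent matters. For compound 3 a step toward a higher number is expected, a 4.2-fold higher number from compound 2 to compound 3 (0.62 log units; beyond the scatter). Compound 3 is therefore estimated at 5 nM, in the range 1.5 nM to 20 nM.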

Compound 3, inhibition constant: 6.7 nM
Estimate against measurement, compound 3: 1.3-fold (0.13 log units) below, and the stated range covers the measured number.
By their numbers in this assay, from the lowest: compound 2; then compounds 3 and 1 (each within the scatter of the next).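

In this assay the swap from 3-chlorophenyl to 4-methoxyphenyl on this chain carbon gives a 5.6-fold higher number from compound 2 to compound 3 (0.75 log units; beyond the scatter) and so does not hold the level of the chlorinated compound. Against 3-fluorophenyl, the same group gives a 1.5-fold lower number from compound 1 to compound 3 (0.17 log units; within the scatter) and the two aryl groups cannot be told apart here. No supporting data bear on why these aryl groups differ. The swap changes both the substituent and where it stands on the ring, and the compounds shown do not separate these two changes. Also open, going by these compounds, is how plain phenyl or a ring carrying a carboxylic acid would behave on this carbon.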